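Halogen swap on the amide-bound phenyl in a gastric cancer cell assay

The compounds below may be only part of what the source reports. "The series", "measured", "known", "first", "only" and "open" are said of these compounds alone.

Compound 1 `O=C(CSc1nc(Nc2ccccc2)c2ccccc2n1)Nc1ccccc1F`: 10700 nM
Compound 2 `O=C(CSc1nc(Nc2ccccc2)c2ccccc2n1)Nc1ccccc1Cl`: 24800 nM
Compound 3 `O=C(CSc1nc(Nc2ccccc2)c2ccccc2n1)Nc1ccccc1Br`: 18600 nM

These three compounds share a core and differ only in the halogen on the phenyl attached to the amide nitrogen. In a functional assay on MGC-803 cells (Homo sapiens) for inhibition, read by MTT assay, with a stated time of 72 h (a higher number here means a weaker inhibitor, a lower number a stronger inhibitor), compound 3 gives 18600 nM, the second highest of the three numbers. Its nearest neighbour is compound 2, with a 1.3-fold lower number from compound 2 to compound 3 (0.12 log units; within the scatter), and its furthest is compound 1, with a 1.7-fold higher number from compound 1 to compound 3 (0.24 log units; within the scatter). Going by the values given here, the only step among the three that exceeds the scatter is a 2.3-fold higher number from compound 1 to compound 2 (0.37 log units; beyond the scatter).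

Compound 4 `O=C(CSc1nc(Nc2ccccc2)c2ccccc2n1)Nc1cccc(F)c1` has not yet been measured. It differs from compound 3 by 3-fluorophenyl in place of 2-bromophenyl on an amide-type nitrogen. Two things change at once: bromine gives way to fluorine, and the halogen sits at a different position on the phenyl ring. The measured steps speak only to the first of these. The step of a 1.7-fold higher number from compound 1 to compound 3 (0.24 log units; within the scatter) shows that exchanging fluoro and bromo at the same position hardly moved the number, so reversing it should likewise be small. Among the compounds with values here, nothing among the measured compounds tells how moving the halogen to a new position will act, so that part is unaccounted for.

Compound 4 is therefore expected to give 13000 nM, with a range from 5000 nM to 35000 nM. The expected step is a 1.4-fold lower number from compound 3 to compound 4 (0.16 log units; within the scatter), leaning slightly toward a lower number but not clearly beyond the scatter.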

Compound 4, half-maximal inhibitory concentration: 12700 nM
For compound 4 the middle estimate is 1.0-fold (0.01 log units) above the measured one; the range from low to high includes it.
By their numbers in this assay, from the lowest: compounds 1, 4, 3 and 2 (each within the scatter of the next, the first and the last beyond it).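

In this assay the step from the 2-fluorophenyl to the 3-fluorophenyl on the amide-type nitrogen keeps the halogen and alters only its place on the ring, and it reads as a 1.2-fold higher number from compound 1 to compound 4 (0.07 log units; within the scatter) so this shift of the fluorine alone does not move the number past the scatter. The two steps that change both halogen and place, a 1.5-fold lower number from compound 3 to compound 4 (0.17 log units; within the scatter) and a 2.0-fold lower number from compound 2 to compound 4 (0.29 log units; within the scatter), also stay within the scatter, so compound 4 cannot be told apart from any of the three earlier compounds, even though compound 1 and compound 2 are separated from each other. No measurement at hand says anything about what lies behind these numbers.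

The compounds shown leave open whether chloro or bromo would behave as fluoro does when placed as in compound 4, since only fluoro is seen at that ring position. They also leave open how this phenyl would respond to a group other than a halogen, such as a methoxy group, an amine or a carboxylic acid, as all four compounds carry a single halogen there.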